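The source may report more compounds than this note shows. Statements on the series, on what has been measured and on what is new or still open speak of the compounds shown alone.

Measured compounds:
compound 1 `NC(=O)c1c(NC(=O)c2ccccc2Cl)sc2c1CCNC2`, which in a functional assay on HeLa cells (Homo sapiens) for antiproliferative activity, with a stated time of 24 h (on this read-out lower numbers stand for stronger inhibition and higher numbers for weaker inhibition), gives 45000 nM;
compound 2 `NC(=O)c1c(NC(=O)c2ccccc2Cl)sc2c1CCN(C(=S)Nc1ccccc1)C2`, which in this assay gives 46700 nM;
compound 3 `NC(=O)c1c(NC(=O)c2ccccc2Cl)sc2c1CCN(C(=O)Nc1c(Cl)cccc1Cl)C2`, which in this assay gives 27200 nM.

Compound 3 gives the lowest of the three numbers, but its distance to the others is small: a 1.7-fold lower number from compound 1 to compound 3 (0.22 log units; within the scatter) and a 1.7-fold lower number from compound 2 to compound 3 (0.23 log units; within the scatter), both within the scatter. The three compounds share a core and differ only in what sits on the amine nitrogen in the ring, and across that position the numbers barely move, as a 1.0-fold higher number from compound 1 to compound 2 (0.02 log units; within the scatter) also shows.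

Compound 4 `NC(=O)c1c(NC(=O)c2ccccc2Cl)sc2c1CCN(C(=S)Nc1cccnc1)C2` continues the series at the same position: a group of 9 heavy atoms (6 carbon, 2 nitrogen, 1 sulfur; one six-membered aromatic ring with 1 hetero atom) in place of a group of 11 heavy atoms (7 carbon, 1 nitrogen, 1 oxygen, 2 chlorine; one six-membered aromatic ring of carbon only), on an amine nitrogen in a ring. The step from compound 2 to compound 3 bears on it most directly, since compound 2 also carries a thiocarbamoyl group with an aromatic ring at that nitrogen, and that step was small. Together with the flat picture from compound 1 to compound 2, nothing here points to a step beyond the scatter in this assay for compound 4, in either direction.

Compound 4 is therefore expected to give about 40000 nM in this assay, with a range from 15000 nM to 110000 nM. The expected step is a 1.5-fold higher number from compound 3 to compound 4 (0.17 log units; within the scatter), a number somewhat closer to that of compound 2 than to that of compound 3, but still within the scatter.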

Compound 4, half-maximal inhibitory concentration: > 50000 nM
Compound 4: only a limit was reported (the forecaster's own chance of this, stated with the estimate: 10%); at least 1.2-fold (0.09 log units) between middle value and limit.
By their numbers in this assay, from the lowest: compounds 3, 1 and 2 (each within the scatter of the next). At a limit, above all of these: compound 4.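

In this assay compound 4 gives only a limit, not a number: the limit of > 50000 nM in this assay, at which 1 of the 4 values shown sits. Its steps are therefore floors, all within the scatter: an at least 1.0-fold higher number from compound 2 to compound 4 (0.02 log units; that floor lies within the scatter) for pyridin-3-yl in place of phenyl on an amide-type nitrogen, an at least 1.1-fold higher number from compound 1 to compound 4 (0.04 log units; that floor lies within the scatter) against the unsubstituted amine nitrogen, and an at least 1.8-fold higher number from compound 3 to compound 4 (0.26 log units; that floor lies within the scatter) against the (2,6-dichlorophenyl)carbamoyl group. The pair of compound 2 and compound 4 is the only one shown that differs in the aromatic ring alone, and it adds that a ring with one hetero atom in place of a ring of carbon only gives no sign in this assay of a number lower than that of compound 2, though the limit hides how far compound 4 actually lies from the others.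

The compounds shown leave open whether any group on this ring nitrogen can move the number beyond the scatter, for instance a longer alkyl chain, a carboxylic acid or a basic amine on the aromatic ring. They also leave apart the two parts of the step to compound 3, since the exchange of sulfur for oxygen and the two chlorines arrive there together.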